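A few compounds are considered here, and "the series" means these few. Any claim that something is new, unique, unknown or untested is made for them only; others in the source may bear on it.

Measured so far, with largest response reached in a functional assay on CHO-K1 cells with Glucose-dependent insulinotropic receptor (Homo sapiens) as the target, read by a luciferase reporter, with a stated time of 5 h; a lower number here means a smaller maximal response, a higher number a larger maximal response:

compound 1, `CC(C)OC(=O)N1CCC(Oc2ncnc3c2CCN3c2ccc(C#N)cn2)CC1`: 105%
compound 2, `CC(C)OC(=O)N1CCC(Oc2ncnc3c2CCN3c2ccc([S@+](C)[O-])c(F)c2)CC1`: 122%
compound 3, `Cc1cc(S(C)(=O)=O)ccc1N1CCc2c(OC3CCN(C(=O)OC(C)C)CC3)ncnc21`: not yet measured

Compound 2 stands highest of the two numbers in this assay; the nearest is compound 1, and the step of a number 17 percentage points higher from compound 1 to compound 2 (beyond the scatter) lies beyond the scatter. Among the compounds with values here, that step swapped the group on the nitrogen on an aromatic ring in a ring for a different one, and it is the only measured step in this set.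

Compound 3 arises from compound 2 by a group of 11 heavy atoms (8 carbon, 2 oxygen, 1 sulfur; one six-membered aromatic ring of carbon only) in place of a group of 10 heavy atoms (7 carbon, 1 oxygen, 1 fluorine, 1 sulfur; one six-membered aromatic ring of carbon only), on a nitrogen on an aromatic ring in a ring

Within the data shown here, both groups are six-membered aromatic rings of carbon only carrying a sulfur-bearing substituent, so the change is smaller in kind than the one from compound 1 to compound 2. Among the measured compounds shown here, no measured step follows this exact exchange, so the only guide is that compound 2 already sits high in this assay and that ring changes of this type moved the number modestly. A step of a number 7 percentage points lower from compound 2 to compound 3 (within the scatter) is therefore expected, within the scatter. Compound 3 is estimated at 115% in this assay, within 95% to 135%.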

Compound 3, largest response reached (reported as percent of maximum), in percent of the reference or control that the assay uses: 80%
Compound 3: middle estimate off by 35 percentage points, on the high side, outside the stated range (below it).
By their numbers in this assay, from the lowest: compound 3; then compound 1; then compound 2.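

Within this assay, the group on this nitrogen proves sensitive even when one six-membered carbon-only aromatic ring replaces another and both carry a sulfur-bearing substituent: the exchange gives a number 42 percentage points lower from compound 2 to compound 3 (beyond the scatter), a large change. Placing 2-methyl-4-(methylsulfonyl)phenyl in the position of 5-cyanopyridin-2-yl gives a number 25 percentage points lower from compound 1 to compound 3 (beyond the scatter), whereas the earlier exchange at this position gave a number 17 percentage points higher from compound 1 to compound 2 (beyond the scatter), so the same position can shift the maximal response in either direction. Nothing available explains the size or direction of these changes.

The step from compound 2 to compound 3 alters several features at once: fluorine leaves, a methyl group enters, the sulfur substituent changes and the defined stereocentre disappears, so the compounds shown cannot assign the drop to any one of these features. A ring carrying methylsulfonyl together with fluorine rather than methyl would separate two of these features, while an amine or a carboxylic acid in place of the sulfur-bearing substituent would test whether sulfur is needed at all.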